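Compound 3 set against a level pair

A few compounds are considered here, and "the series" means these few. Any claim that something is new, unique, unknown or untested is made for them only; others in the source may bear on it.

Of the compounds shown here, two have numbers so far. In a functional assay on NCI-H460 cells (Homo sapiens) for inhibition, read by sulforhodamine B assay, with a stated time of 48 h (a higher number here means a weaker inhibitor of growth, a lower number a stronger inhibitor of growth), compound 1 `COc1cccc(C(=O)NNC(=O)c2ccc3[nH]c(-c4ccc([N+](=O)[O-])o4)nc3c2)c1` gives 62.5 ug/mL and compound 2 `O=C(NNC(=O)c1cc2ccccc2cc1O)c1ccc2[nH]c(-c3ccc([N+](=O)[O-])s3)nc2c1` gives 62.5 ug/mL on the same read-out. Compound 2 therefore stands level with compound 1, within the scatter. The series holds no measured pair that differs in one place, so the size of a single structural change in this assay has not been shown directly.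

Compound 3 `COc1cccc(C(=O)NNC(=O)c2ccc3[nH]c(-c4ccc([N+](=O)[O-])s4)nc3c2)c1` remains to be measured. It differs from compound 2 in one place, with 3-methoxyphenyl in place of 3-hydroxynaphthalen-2-yl on a carbonyl carbon. For the measured compounds named here, the only guide is the level reading of compound 1 at 62.5 ug/mL and compound 2 at 62.5 ug/mL in this series, and it favours no direction. The estimated step of no change at the digits printed from compound 2 to compound 3 (within the scatter) is therefore expected to stay within the scatter in this assay with neither a stronger nor a weaker reading favoured. The expected value for compound 3 is 62.5 ug/mL within a range of 25 ug/mL to 125 ug/mL on repeat measurement.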

Compound 3, concentration for 50% growth inhibition: 62.5 ug/mL
Compound 3: the middle estimate sits on the measured number at the digits printed, within the range that was stated.
By their numbers in this assay, from the lowest: compounds 1, 2 and 3 (each within the scatter of the next).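

In this assay, the series now has its first comparisons that differ in one place: 3-methoxyphenyl in place of 3-hydroxynaphthalen-2-yl on a carbonyl carbon gives no change at the digits printed from compound 2 to compound 3 (within the scatter), and 5-nitrothiophen-2-yl in place of 5-nitrofuran-2-yl on an aromatic carbon gives no change at the digits printed from compound 1 to compound 3 (within the scatter). The two steps share compound 3, so each place has its own reading, which the earlier pair, differing in both places, could not give. At the carbonyl carbon, a group with 2 six-membered aromatic rings of carbon only and 1 hydrogen-bond donor and a group with one such ring and 0 hydrogen-bond donors read level, and no measurement available here bears on the reason for either step.

On these data alone, with only these level readings, it remains open whether either place can shift the reading at all, and a single shared value cannot separate a flat response from a limited range of groups. A carboxylic acid or a saturated amine such as piperidin-1-yl on the carbonyl carbon, or a plain thiophen-2-yl without the nitro group on the aromatic carbon, would test these two places more sharply.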